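The compounds below may be only part of what the source reports. "The series", "measured", "known", "first", "only" and "open" are said of these compounds alone.

Of the compounds shown here, three built on a shared core have been tested in a functional assay on BT-474 cells (Homo sapiens) for antiproliferative activity, read by CCK-8 assay, with a stated time of 72 h; a higher number here means a weaker inhibitor, a lower number a stronger inhibitor. Compound 1 `O=C(c1ccncc1)N1N=C(c2ccc(Cl)cc2)CC1c1ccco1` gives 6500 nM in this assay. Compound 3 `COc1ccc(C2CC(c3ccccc3)=NN2C(=O)c2nc3ccccc3s2)cc1` gives 6300 nM. These are the only two numbers shown, and the number of compound 1 lies within the scatter of that of compound 3, so neither can be set above the other. Compound 2 `COc1ccccc1C1=NN(C(=O)c2ccc([N+](=O)[O-])o2)C(c2ccc([N+](=O)[O-])cc2)C1` reaches only a limit of the assay, > 50000 nM. This is the limit of > 50000 nM in this assay, at which 1 of the 3 values shown sits.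

Compound 4 `COc1ccc(C2CC(c3ccccc3)=NN2C(=O)c2ccncc2)cc1` has not yet been measured in this assay. It differs from compound 3 in one place: pyridin-4-yl in place of 1,3-benzothiazol-2-yl on a carbonyl carbon. For the measured compounds named here, no pair of measured compounds differing in one place is available, so the effect of this change cannot be read from a measured step. Compound 1, which also carries a pyridin-4-yl on its carbonyl carbon, gives 6500 nM, close to the number of compound 3. The expected step is therefore a 1.1-fold higher number from compound 3 to compound 4 (0.05 log units; within the scatter), none beyond the scatter. Compound 4 is expected to give 7000 nM, with a range from 3000 nM to 20000 nM.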

Compound 4, half-maximal inhibitory concentration: > 50000 nM
Compound 4: no number, only a limit; the forecaster's own chance of this, stated with the estimate: 10%; middle value at least 7.1-fold (0.85 log units) from the limit.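

For the compounds shown here, this is the first measured step, and it shows that the group on the carbonyl carbon can decide whether activity is seen on this core: in this assay, pyridin-4-yl in place of 1,3-benzothiazol-2-yl gives an at least 7.9-fold higher number from compound 3 to compound 4 (0.89 log units; beyond the scatter). The step has only a lower bound, so the real loss may be larger than printed. Compound 4 gives no number, only a limit of the assay: the limit of > 50000 nM in this assay, at which 2 of the 4 values shown sit.

The compounds shown do not tell which part of the 1,3-benzothiazol-2-yl group carries the activity of compound 3, whether its carbon-only ring, its sulfur or its ring nitrogen. A plain phenyl, or a 1,3-benzoxazol-2-yl with oxygen in place of that sulfur, on the same carbonyl carbon would begin to separate these parts.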